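A New Benzyl Group on a Compound Without a Number

A few compounds are considered here, and "the series" means these few. Any claim that something is new, unique, unknown or untested is made for them only; others in the source may bear on it.

In a functional assay on B16 cells (Mus musculus) for antiproliferative activity, with a stated time of 72 h (on this read-out higher numbers stand for weaker inhibition and lower numbers for stronger inhibition), compound 1 (`OC[C@H]1O[C@@H](n2cnc3c(NCc4ccccc4F)ncnc32)[C@H](O)[C@@H]1O`) gives > 166000 nM as its reading, which is a limit and not a number. Compound 2 (`COc1ccc(CNc2ncnc3c2ncn3[C@@H]2O[C@H](CO)[C@@H](O)[C@H]2O)c(OC)c1`) carries the entry "not determined" (no result reported) in this test. Compound 3 (`OC[C@H]1O[C@@H](n2cnc3c(NCc4cc(O)cc(O)c4)ncnc32)[C@H](O)[C@@H]1O`) carries the entry "not determined" (no result reported) as well, so it has no place on the scale. Compound 4 (`Cc1cccc(CNc2ncnc3c2ncn3[C@@H]2O[C@H](CO)[C@@H](O)[C@H]2O)c1O`) comes next. The change 2-hydroxy-3-methylphenyl in place of 3,5-dihydroxyphenyl on a saturated chain carbon bound to a nitrogen on an aromatic ring sits on a saturated chain carbon bound to a nitrogen on an aromatic ring. Within the data shown here, with no number for compound 3, no step can be sized from it. Still, a clear move toward stronger inhibition than the limit of compound 1 is expected, though a reading at that limit remains possible. In this assay compound 4 is estimated at 30000 nM with an expected range of 2000 nM to 166000 nM for this reading.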

Compound 4, half-maximal inhibitory concentration: > 166000 nM
Compound 4: a limit, no number; the forecaster's own chance of this, stated with the estimate: 40%; middle value at least 5.5-fold (0.74 log units) from the limit.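

No step from compound 1 to compound 4 can be read in this assay, because both readings are limits and not numbers: the limit of > 166000 nM in this assay, at which 2 of the 4 values shown sit.

The compounds shown leave open which benzyl group, if any, gives a true number on this scale.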